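The source may hold more compounds than are shown below. What is called first, only, known or untested is meant among the compounds shown, and "the series" means these compounds.

Measured so far in an ADME assay on BHK-21 cells (Mesocricetus auratus) for cytotoxicity, read by MTT assay, with a stated time of 72 h; a lower number here means that less compound is tolerated, a higher number that more compound is tolerated:
- compound 1 `NS(=O)(=O)c1ccc(N2N=C(c3ccccc3)CC2c2ccccc2F)cc1`: 21000 nM
- compound 2 `Cc1ccc(C2CC(c3ccccc3)=NN2c2ccc(S(N)(=O)=O)cc2)cc1`: 7000 nM

Compound 2 has the lower of the two numbers, and the gap to compound 1 is beyond the scatter. The next compound is compound 3 `NS(=O)(=O)c1ccc(N2N=C(c3ccccc3)CC2c2ccccc2Cl)cc1`, with 2-chlorophenyl in place of 4-methylphenyl on a saturated ring carbon. Among the compounds with values here, one measured step bears on this change: a 3.0-fold lower number from compound 1 to compound 2 (0.48 log units; beyond the scatter), a modest step with 4-methylphenyl in place of 2-fluorophenyl. Within the data shown here, compound 3 also loses 4-methylphenyl, but no measurement yet compares 2-chlorophenyl with 2-fluorophenyl. A higher number is therefore expected in this assay, by a similar or somewhat smaller amount, and the estimated size is a 2.1-fold higher number from compound 2 to compound 3 (0.33 log units; beyond the scatter). For compound 3 the estimated value is 15000 nM, with an expected range of 6000 nM to 40000 nM.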

Compound 3, half-maximal cytotoxic concentration: 13000 nM
Estimate against measurement, compound 3: 1.2-fold (0.06 log units) above, and the stated range covers the measured number.
By their numbers in this assay, from the lowest: compounds 2, 3 and 1 (each within the scatter of the next, the first and the last beyond it).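

In this assay, 2-chlorophenyl in place of 4-methylphenyl on the saturated ring carbon gives a 1.9-fold higher number from compound 2 to compound 3 (0.27 log units; within the scatter), so this exchange does not separate the two groups. Chloro in place of fluoro on the aromatic carbon gives a 1.6-fold lower number from compound 1 to compound 3 (0.21 log units; within the scatter), the first direct comparison of the two halogens here, and it does not separate them either. Compound 3 therefore lies within the scatter of both neighbours, although compound 1 and compound 2 remain apart, and no measured evidence bears on this result.

The compounds shown leave open whether the gap between compound 1 and compound 2 follows the methyl group or its place on the ring, which 2-methylphenyl and 4-chlorophenyl would test. Also open, going by these compounds, is how an amine or a carboxylic acid on this phenyl ring would read.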